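Shifting a Methyl Group: Expected Potency of Compound 4

The source may hold more compounds than are shown below. What is called first, only, known or untested is meant among the compounds shown, and "the series" means these compounds.

Four closely related compounds are compared in a functional assay on RPMI 8402 cells (Homo sapiens) for cytotoxicity; on this read-out higher numbers stand for weaker inhibition and lower numbers for stronger inhibition. Compound 1 `Cc1cccc(-c2nc3cc(-c4nc5cc(C#N)ccc5[nH]4)ccc3[nH]2)c1` gives 860 nM. Compound 2 `Cc1ccc(-c2nc3cc(-c4nc5cc(C#N)ccc5[nH]4)ccc3[nH]2)cc1` gives 570 nM. Compound 3 `Cc1cccc(-c2nc3cc(-c4nc5cc(C(N)=O)ccc5[nH]4)ccc3[nH]2)c1` gives 8200 nM, the highest of the three numbers. Compound 4 `Cc1ccc(-c2nc3cc(-c4nc5cc(C(N)=O)ccc5[nH]4)ccc3[nH]2)cc1` has not yet been tested.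

Compound 2 differs from compound 1 by one change: 4-methylphenyl in place of 3-methylphenyl on an aromatic carbon This change gave a 1.5-fold lower number from compound 1 to compound 2 (0.18 log units; within the scatter), so the two compounds cannot be told apart on this read-out.

Compound 3 differs from compound 1 by a different change: carbamoyl in place of cyano on an aromatic carbon This change gave a 9.5-fold higher number from compound 1 to compound 3 (0.98 log units; beyond the scatter), a clear weakening.

Compound 4 relates to compound 3 exactly as compound 2 relates to compound 1: 4-methylphenyl in place of 3-methylphenyl on an aromatic carbon The surroundings of the two changes read the same word for word, so this is the same change, now made on the weaker pair carrying the carbamoyl group. In this assay the step is expected to be a 1.5-fold lower number from compound 3 to compound 4 (0.17 log units; within the scatter), because the same change gave a 1.5-fold lower number from compound 1 to compound 2 (0.18 log units; within the scatter). Compound 4 is therefore expected at about 5600 nM, with a likely range from 2500 nM to 13000 nM. This expectation rests on a single measured pair, and whether the change behaves the same way on the carbamoyl compounds is not known until compound 4 is measured.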

Compound 4, half-maximal inhibitory concentration: > 25000 nM
Compound 4 ended at the assay's limit (the forecaster's own chance of this, stated with the estimate: 10%); middle value at least 4.4-fold (0.64 log units) away from the limit.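

On the cyano core, moving the methyl group made no readable difference, but on the carbamoyl core the same move gave an at least 3.0-fold higher number from compound 3 to compound 4 (0.48 log units; beyond the scatter), so in this assay this change did not carry over from one core to the other: the same change on two cores in this assay, a 1.5-fold lower number (0.18 log units; within the scatter) from compound 1 to compound 2 and an at least 3.0-fold higher number (0.48 log units; beyond the scatter) from compound 3 to compound 4, at least 4.5-fold (0.66 log units) apart, beyond the scatter of two such steps

Read the other way, replacing cyano with carbamoyl gave an at least 43-fold higher number from compound 2 to compound 4 (1.64 log units; beyond the scatter), which shows that this swap also depends on its surroundings, as it cost more with 4-methylphenyl in place than with 3-methylphenyl: the same change on two cores in this assay, a 9.5-fold higher number (0.98 log units; beyond the scatter) from compound 1 to compound 3 and an at least 43-fold higher number (1.64 log units; beyond the scatter) from compound 2 to compound 4, at least 4.5-fold (0.66 log units) apart, beyond the scatter of two such steps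

For compound 4, the reading of > 25000 nM is a limit of the assay and not a number, so the true size of both new steps stays unknown, and these two pairs of compounds neither explain the mismatch nor give a rule for other cores: the limit of > 25000 nM in this assay, at which 1 of the 4 values shown sits.

The compounds shown leave open whether a carboxylic acid or an amine in place of the carbamoyl group would also make the effect of moving the methyl group depend on the core. They also leave open whether a longer chain, such as ethyl, in place of the methyl group would follow the same pattern on either core.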